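The source may report more compounds than this note shows. Statements on the series, on what has been measured and on what is new or still open speak of the compounds shown alone.

Compound 1 `O=C(O)c1ccc(C(=O)/C(=C\c2ccc(F)c([N+](=O)[O-])c2)SCc2ccc(C(F)(F)F)cc2)cc1`: 1000 nM
Compound 2 `O=C(O)c1ccc(C(=O)/C(=C\c2ccc(F)c([N+](=O)[O-])c2)SCc2ccc(F)cc2)cc1`: 1000 nM

In a functional assay on DU-145 cells (Homo sapiens) for inhibition, read by trypan blue exclusion, with a stated time of 96 h (on this read-out lower numbers stand for stronger inhibition of growth and higher numbers for weaker inhibition of growth), compound 2 gives 1000 nM, level with compound 1 at 1000 nM. Compound 3 `CC(=O)Nc1ccc(/C=C(/SCc2ccc(F)cc2)C(=O)c2ccc(C(=O)O)cc2)cc1[N+](=O)[O-]` carries acetamido in place of fluoro on an aromatic carbon, ortho to a nitro group (acetamido in place of fluoro on an aromatic carbon). Among the compounds with values here, the only measured step, no change at the digits printed from compound 1 to compound 2 (within the scatter), replaces a different group elsewhere in the molecule, so it bears only indirectly. Within the data shown here, no measured step changes this position, so no direction can be argued in this assay. The expected outcome is no change at the digits printed from compound 2 to compound 3 (within the scatter), with wide uncertainty. For compound 3 the estimate is 1000 nM, with an expected range of 300 nM to 3000 nM.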

Compound 3, concentration for 50% growth inhibition: 10000 nM
Compound 3: middle estimate off by 10-fold (1.00 log units), on the low side; measured number outside the range, above it.
By their numbers in this assay, from the lowest: compounds 1 and 2 (each within the scatter of the next); then compound 3.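

In this assay, within the data shown here, this position, ortho to a nitro group, is the first place where a replacement registers: acetamido in place of fluoro gives a 10-fold higher number from compound 2 to compound 3 (1.00 log units; beyond the scatter). The earlier pair had shown no separation, so the result shows that the shared core does not accept every change equally. Growth inhibition weakens here, but no measurement on hand accounts for the shift. The compounds shown leave open how an amine or a methoxy group would read at this position, and whether acetamido would produce the same step on compound 1.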